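A few compounds are considered here, and "the series" means these few. Any claim that something is new, unique, unknown or untested is made for them only; others in the source may bear on it.

Measured compounds in a functional assay (brain) for inhibition, with Rattus norvegicus as the target; a lower number here means a stronger inhibitor, a higher number a weaker inhibitor:
compound 1 `Cc1c(C)c2c(c(C)c1O)CC[C@@](C)(CC(=O)O)O2` gives 17000 nM
compound 2 `Cc1c(C)c2c(c(C)c1O)CC[C@@](C)(CC(=O)[N-][N+](C)(C)C)O2` gives 9000 nM
compound 3 `Cc1c(C)c2c(c(C)c1O)CC[C@](C)(CC(=O)O)O2` gives 14000 nM

Compound 1 and compound 3 share all atoms and bonds; the difference between the two cores is the two compounds have the same atoms and bonds and differ only in configuration as drawn: 1 of 1 stereo elements differ; a stereocentre at a saturated ring carbon is drawn S in compound 1 and R in compound 3. Within the data shown here, this is the only change from compound 1 to compound 3, and in this assay it gives a 1.2-fold lower number from compound 1 to compound 3 (0.08 log units; within the scatter), so the two configurations cannot be told apart here, a point that follows from the fact that compounds 1 and 3 differ only in the configuration as drawn.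

The change from compound 1 to compound 2 is a group of 5 heavy atoms (3 carbon, 2 nitrogen; no ring) in place of one oxygen atom, on a carbonyl carbon. In this assay this gives a 1.9-fold lower number from compound 1 to compound 2 (0.28 log units; within the scatter).

Compound 4 `Cc1c(C)c2c(c(C)c1O)CC[C@](C)(CC(=O)[N-][N+](C)(C)C)O2` is not yet measured. It stands to compound 3 as compound 2 stands to compound 1: the change is a group of 5 heavy atoms (3 carbon, 2 nitrogen; no ring) in place of one oxygen atom, on a carbonyl carbon, with the place described in the same words for both pairs, so it is the same change made on the other core. It occurs twice among the compounds shown, once measured and once not.

The expectation for compound 4 in this assay rests on two things: the value of compound 3, 14000 nM, as the starting point, and the size of the measured step from compound 1 to compound 2, a 1.9-fold lower number from compound 1 to compound 2 (0.28 log units; within the scatter), as the likely size of the change. Since the step between the two cores, a 1.2-fold lower number from compound 1 to compound 3 (0.08 log units; within the scatter), lies within the scatter, the two cores are treated as equivalent starting points. For compound 4 a step of about a 1.9-fold lower number from compound 3 to compound 4 (0.27 log units; within the scatter) is therefore expected. Compound 4 is estimated at 7500 nM, with a range from 3500 nM to 16000 nM.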

Compound 4, half-maximal inhibitory concentration: 8000 nM
The estimate for compound 4 lay 1.1-fold (0.03 log units) below the measured number; the range from low to high includes it.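

In this assay, putting the group of 5 heavy atoms in place of hydroxy on a carbonyl carbon gives a 1.8-fold lower number from compound 3 to compound 4 (0.24 log units; within the scatter), and this step matches the one measured on the other core: the same change on two cores in this assay, a 1.9-fold lower number (0.28 log units; within the scatter) from compound 1 to compound 2 and a 1.8-fold lower number (0.24 log units; within the scatter) from compound 3 to compound 4, 1.1-fold (0.03 log units) apart, within the scatter of two such steps. With the new group in place, the two configurations again cannot be told apart, with a 1.1-fold lower number from compound 2 to compound 4 (0.05 log units; within the scatter), so the two drawn configurations behave as equivalent cores for this change: the fact that compounds 2 and 4 differ only in the configuration as drawn. Among these compounds, this shows only that the step has the same size on two cores that differ in a single stereocentre; since each step lies within the scatter, it does not show that the change has a real effect on either core, and it says nothing about carrying the change to a core that differs in its atoms.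

The compounds shown leave open whether any group on this carbonyl carbon can move the number beyond the scatter, for example an amine, a methyl ester or a primary amide in place of hydroxy. They also leave open whether a longer chain leading to the carbonyl carbon would separate the two configurations in this assay.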